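Series notes: cyclohexyl linker replacing ethyl on compound 3

The source may hold more compounds than are shown below. What is called first, only, known or untested is meant among the compounds shown, and "the series" means these compounds.

Compound 3 `Fc1cccnc1Nc1ncc(-c2cnc3ccc(NCCN4CCCC4)nn23)cn1` gives 1.5 in a physicochemical assay for lipophilicity; a lower number here means a more polar compound, a higher number a more lipophilic compound. Compound 1 `CN1CC[C@H](Nc2ccc3ncc(-c4cnc(Nc5ncccc5F)nc4)n3n2)C1` gives 1.5 in this assay, and compound 2 `CN1CCN(CCNc2ccc3ncc(-c4cnc(Nc5ncccc5F)nc4)n3n2)CC1` gives 1.6. The measured steps are no change at the digits printed from compound 1 to compound 3 (within the scatter), a number 0.10 log units lower from compound 2 to compound 3 (within the scatter) and a number 0.10 log units higher from compound 1 to compound 2 (within the scatter). Compound 3 therefore stands level with compound 1, the two together the lowest of the three numbers, with compound 2 the furthest of the set, all within the scatter.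

Compound 4 `Fc1cccnc1Nc1ncc(-c2cnc3ccc(N[C@H]4CC[C@H](N5CCCC5)CC4)nn23)cn1` awaits measurement in this assay. The change is 4-(pyrrolidin-1-yl)cyclohexyl in place of 2-(pyrrolidin-1-yl)ethyl on a nitrogen on an aromatic ring. The three measured steps each exchanged one amine-bearing substituent on the aromatic nitrogen for another of comparable size and stayed within the scatter; none of them replaces a two-carbon chain with a saturated carbon ring, so they do not directly cover this change. The entering group is larger by the count shown and carries the same single acceptor, which points to a rise in this assay beyond the scatter.

Compound 4 is expected to give 2.3 in this assay, with a range of 1.8 to 2.9. The expected step is a number 0.80 log units higher from compound 3 to compound 4 (beyond the scatter).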

Compound 4, distribution coefficient: 1.9
For compound 4 the middle estimate is 0.40 log units above the measured one; measured number inside the range.
By their numbers in this assay, from the lowest: compounds 1, 3, 2 and 4 (each within the scatter of the next, the first and the last beyond it).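

In this assay, 4-(pyrrolidin-1-yl)cyclohexyl in place of 2-(pyrrolidin-1-yl)ethyl on a nitrogen on an aromatic ring gives a number 0.40 log units higher from compound 3 to compound 4 (beyond the scatter) and so passes the scatter, which none of the steps among compound 1, compound 2 and compound 3 did. The comparison with the 1-methylpyrrolidin-3-yl group reads the same, at a number 0.40 log units higher from compound 1 to compound 4 (beyond the scatter) for this exchange, whereas the comparison with the 2-(4-methylpiperazin-1-yl)ethyl group gives a number 0.30 log units higher from compound 2 to compound 4 (within the scatter) and so does not pass it, which makes the response at this position modest and dependent on the comparison. No measurement on hand accounts for these steps.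

On these data alone, whether the step follows the carbon ring itself or only the larger group stays open, and a longer chain ending in pyrrolidin-1-yl would separate the two. Also open, as far as these compounds go, is how 4-(4-methylpiperazin-1-yl)cyclohexyl would read in this assay on the same core.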